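A nitrophenyl-to-furanyl swap on the shared core

The source may report more compounds than this note shows. Statements on the series, on what has been measured and on what is new or still open speak of the compounds shown alone.

Measured so far:
Compound 1, `CC1=C(C(=O)OCc2cccnc2)C(c2ccccc2[N+](=O)[O-])C2=C(CCCC2=O)N1`, gives 1.51 in a physicochemical assay for lipophilicity, measured as octanol-water partition; on this read-out lower numbers stand for lower lipophilicity and higher numbers for higher lipophilicity.
Compound 2, `CC1=C(C(=O)OCc2ccccn2)C(c2cccs2)C2=C(CCCC2=O)N1`, gives 1.77 in this assay.
Compound 3, `CC1=C(C(=O)OCc2ccccn2)C(c2ccccc2[N+](=O)[O-])C2=C(CCCC2=O)N1`, gives 1.88 in this assay.

Compound 1 stands lowest of the three numbers in this assay. Its nearest neighbour is compound 2, whose number sits within the scatter of compound 1, while compound 3 lies furthest, the step of a number 0.37 log units higher from compound 1 to compound 3 (beyond the scatter) being beyond the scatter.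

Compound 4, `CC1=C(C(=O)OCc2cccnc2)C(c2ccco2)C2=C(CCCC2=O)N1`, is not yet measured. It differs from compound 1 in one place: furan-2-yl in place of 2-nitrophenyl on a saturated ring carbon.

Within the data shown here, one measured step bears on this change, though only in part: a number 0.11 log units higher from compound 2 to compound 3 (within the scatter), which stays within the scatter. Among the measured compounds shown here, no measured step involves furan-2-yl, so the account rests on that one comparison. The expectation for compound 4 is therefore no step beyond the scatter in this assay, leaning if anything slightly lower, as the estimated step of a number 0.16 log units lower from compound 1 to compound 4 (within the scatter) expresses. Compound 4 is estimated at 1.35, within a range from 0.95 to 1.75.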

Compound 4, partition coefficient: 1.03
The estimate for compound 4 lay 0.32 log units above the measured number; the measured number falls inside the stated range.
By their numbers in this assay, from the lowest: compound 4; then compounds 1, 2 and 3 (each within the scatter of the next, the first and the last beyond it).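

On the saturated ring carbon, the replacement of 2-nitrophenyl by furan-2-yl gives, in this assay, a number 0.48 log units lower from compound 1 to compound 4 (beyond the scatter), so a change at this position can carry the number beyond the scatter. Among these compounds, the only earlier change at this carbon, from thiophen-2-yl to 2-nitrophenyl alongside the pyridin-2-yl group, gave a number 0.11 log units higher from compound 2 to compound 3 (within the scatter), and it did not show this. Nothing available explains the size of the new step. The compounds shown do not tell whether furan-2-yl would give a similar step alongside the pyridin-2-yl group, since compound 4 carries the pyridin-3-yl group. They also leave open where an unsubstituted phenyl ring or a furan-3-yl group on the same carbon would fall.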